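Two Weak Triterpenoid Esters and an Untested Variant

A few compounds are considered here, and "the series" means these few. Any claim that something is new, unique, unknown or untested is made for them only; others in the source may bear on it.

Compound 1 `CC1=CC[C@H]2[C@H](CC[C@]2(C)O)C(C)(C)[C@@H]1CC[C@H]1[C@]2(C)CC[C@H](OC(=O)c3ccc(C)cc3)C(C)(C)O[C@H]2CC[C@@]1(C)O` and compound 2 `CC(=O)O[C@H]1CC[C@]2(C)[C@H](CC[C@@](C)(O)[C@H]2CC[C@@H]2C(C)=CC[C@@H]3C(C)=CC[C@@H]3C2(C)C)OC1(C)C` share a large polycyclic core and differ only in the ester at one end. In a functional assay on MDA-MB-231 cells (Homo sapiens) for antiproliferative activity, read by MTT assay, with a stated time of 72 h (a lower number here means a stronger inhibitor, a higher number a weaker inhibitor), compound 1 gives 33400 nM, and in this assay compound 2 gives 39200 nM; the two numbers lie within the usual scatter of each other, so neither can be ranked over the other. Compound 3 `CC1=CC[C@H]2[C@H](CC[C@]2(C)O)C(C)(C)[C@@H]1CC[C@H]1[C@]2(C)CC[C@H](OC(=O)c3ccccc3C(F)(F)F)C(C)(C)O[C@H]2CC[C@@]1(C)O` has not yet been measured. It differs from compound 1 by 2-(trifluoromethyl)phenyl in place of 4-methylphenyl on a carbonyl carbon. Within the data shown here, with no measured step for such a change to lean on, compound 3 is expected to stay close to compound 1, with a step of a 1.1-fold lower number from compound 1 to compound 3 (0.05 log units; within the scatter) of no more than the scatter. Compound 3 is therefore estimated at 30000 nM, within 10000 nM to 90000 nM.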

Compound 3, half-maximal inhibitory concentration: 31500 nM
Beside the measured number, compound 3's estimate is 1.1-fold (0.02 log units) below it, within the range that was stated.
By their numbers in this assay, from the lowest: compounds 3, 1 and 2 (each within the scatter of the next).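

Placing 2-(trifluoromethyl)phenyl where compound 1 carries 4-methylphenyl on a carbonyl carbon gives a 1.1-fold lower number from compound 1 to compound 3 (0.03 log units; within the scatter) in this assay. Two differently substituted phenyl esters therefore cannot be told apart at this position, even though the entering group brings three fluorine atoms. Nothing available accounts for this result.

The compounds shown leave open whether an amine or a carboxylic acid on the phenyl ring would give a different number. They also leave open whether a longer carbon chain in place of the ring would do so.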